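The source may report more compounds than this note shows. Statements on the series, on what has been measured and on what is new or still open speak of the compounds shown alone.

Compound 1, `N#Cc1ccc(Nc2nc(Oc3ccnc4ccccc34)nc(N3CCN(c4ccc(F)cc4)CC3)n2)cc1C(F)(F)F`, in a functional assay on DU-145 cells (Homo sapiens) for cytotoxicity, read by sulforhodamine B assay, with a stated time of 48 h; a higher number here means that more compound is tolerated, a lower number that less compound is tolerated: > 100000 nM, a limit of the assay rather than a number.
Compound 2, `N#Cc1ccc(Nc2nc(Oc3ccnc4ccccc34)nc(N3CCN(c4ccccc4F)CC3)n2)cc1C(F)(F)F`, in this assay: > 100000 nM, likewise a limit and not a number.

The two measured compounds share one core and differ only in whether the phenyl on the ring amine nitrogen is 4-fluorophenyl or 2-fluorophenyl. The step that the two limits leave unreadable from compound 1 to compound 2 cannot be read because of the limit of > 100000 nM in this assay, at which 2 of the 2 values shown sit. Among the compounds with values here, compound 2 therefore stands at the assay limit, as does the one other value shown, and no order between the two can be drawn.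

Compound 3, `N#Cc1ccc(Nc2nc(Oc3ccnc4ccccc34)nc(N3CCN(c4ccccc4)CC3)n2)cc1C(F)(F)F`, carries hydrogen in place of fluoro on an aromatic carbon. Within the data shown here, the single measured step also alters this same phenyl, and its size is unreadable; no measured step gives a direction for the change from compound 2 to compound 3. The expectation is that compound 3 again sits at or beyond the limit, so the step that the limit leaves unreadable from compound 2 to compound 3 is expected to be small or unreadable. Compound 3 is estimated at 150000 nM, with a range from 50000 nM to 500000 nM, most likely reported only as a limit.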

Compound 3, concentration lethal to 50% of the cells: > 100000 nM
Compound 3: a limit, no number (the forecaster's own chance of this, stated with the estimate: 80%); the middle value does not contradict the limit.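

Compound 3 also gives only a limit rather than a number, so no step among compound 1, compound 2 and compound 3 can be read: the limit of > 100000 nM in this assay, at which 3 of the 3 values shown sit.

The compounds shown leave open where each of the three truly stands in this assay, and whether removing or moving the fluoro changes that value at all.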